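This account rests on a few compounds, and the source may have more. Where it says the series, first, only, none or still open, it means among the compounds named here.

Going by the values given here, three amides sharing one core have numbers so far. In a functional assay on cells (Homo sapiens) for antiproliferative activity, read by sulforhodamine B assay, with a stated time of 48 h (a higher number here means a weaker inhibitor, a lower number a stronger inhibitor), compound 1 (`CCCCCCCCCCCCCCCCNC(=O)[C@@H]1CSC(c2ccc(OC)c(OC)c2)N1`) gives 1500 nM while compound 2 (`CCCCCCCCCCCCNC(=O)[C@@H]1CSC(c2ccc(NC(C)=O)cc2)N1`) gives 2400 nM and compound 3 (`CCCCCCCCCCCCCCNC(=O)[C@@H]1CSC(c2ccc(NC(C)=O)cc2)N1`) gives 2300 nM as its value. Compound 3 therefore stands level with the other two, since its gaps to both lie within the usual scatter of repeated measurements.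

The next molecule is compound 4 (`CCCCCCCCCCCCCCCCNC(=O)[C@@H]1CSC(c2ccc(NC(C)=O)cc2)N1`), which differs from compound 3 in one place (ethyl in place of hydrogen on a saturated chain carbon, ten or more bonds along the chain from an amide-type nitrogen) and so carries ethyl in place of hydrogen on a saturated chain carbon, ten or more bonds along the chain from an amide-type nitrogen. The same change has been measured once before (a 1.0-fold lower number from compound 2 to compound 3 (0.02 log units; within the scatter)) and that step stayed within the scatter. A single step is thin evidence, and it cannot show whether the chain can grow further without consequence. Still, it gives no reason to expect a real shift, so no step beyond the scatter is expected in this assay and neither direction is favoured. The expected step is correspondingly small (no change at the digits printed from compound 3 to compound 4 (within the scatter)) on this reading. For compound 4 the estimated value is 2300 nM with an expected range from 1200 nM to 4500 nM as its limits of likelihood.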

Compound 4, half-maximal inhibitory concentration: 2100 nM
Compound 4: the middle estimate sits 1.1-fold (0.04 log units) above what was measured; measured number inside the range.
By their numbers in this assay, from the lowest: compounds 1, 4, 3 and 2 (each within the scatter of the next).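

In this assay the same change at this place on the chain has now been read twice, and the second reading, a 1.1-fold lower number from compound 3 to compound 4 (0.04 log units; within the scatter), also stays within the scatter; the larger difference, butyl in place of hydrogen on a saturated chain carbon, gives a 1.1-fold lower number from compound 2 to compound 4 (0.06 log units; within the scatter) and also stays within it, so across compounds 2, 3 and 4 the chain extension brings no readable shift. Compound 4 also opens a second comparison, at the other end of the molecule: with the chain the same, 4-acetamidophenyl in place of 3,4-dimethoxyphenyl on a saturated ring carbon gives a 1.4-fold higher number from compound 1 to compound 4 (0.15 log units; within the scatter), so this swap brings no readable shift either. Nothing else measured on these compounds offers an explanation for these small steps.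

The compounds shown all carry long unbranched chains, so it remains open whether a much shorter chain such as hexyl, or a chain ending in an amine or a carboxylic acid, would stay in the same range. Going by these compounds alone, on the ring side, only two groups can be compared, and a phenyl bearing a free amine or a nitrile in place of the acetamido group remains an open question.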